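Swapping Furan for Pyrrole on a Shared Fused Core

The source may report more compounds than this note shows. Statements on the series, on what has been measured and on what is new or still open speak of the compounds shown alone.

Measured compounds and their values:
- Compound 1 `COc1ccc(Cl)c(-c2nnc3n2NC(c2ccco2)S3)c1`: 23.1%
- Compound 2 `Cc1occc1-c1nnc2n1NC(c1ccco1)S2`: 24.1%
- Compound 3 `Cc1occc1-c1nnc2n1NC(c1ccc([N+](=O)[O-])o1)S2`: 22.8%

Three compounds sharing one fused core were tested in a functional assay on the whole organism (strain Wistar Albino) for inhibition, with Rattus norvegicus as the target, read by paw edema, with a stated time of 3 h, at a dose of 20 mg/kg; on this read-out higher numbers stand for more inhibition at the one dose given (going by the name of the read-out) and lower numbers for less inhibition. Compound 2 `Cc1occc1-c1nnc2n1NC(c1ccco1)S2` gives 24.1%, compound 1 `COc1ccc(Cl)c(-c2nnc3n2NC(c2ccco2)S3)c1` gives 23.1%, and compound 3 `Cc1occc1-c1nnc2n1NC(c1ccc([N+](=O)[O-])o1)S2` gives 22.8%. Compound 2 holds the highest of the three numbers, but both neighbours sit within the usual scatter of it, so no order among them can be claimed. For the measured compounds named here, the one single-point step measured, a number 1.3 percentage points lower from compound 2 to compound 3 (within the scatter), was a change at an aromatic carbon and moved nothing beyond the scatter.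

Compound 4 `Cc1occc1-c1nnc2n1NC(c1ccc[nH]1)S2` differs from compound 2 by 1H-pyrrol-2-yl in place of furan-2-yl on a saturated ring carbon. Going by the values given here, this exchange on a saturated ring carbon has no measured counterpart here, so the only guidance is that the single measured step left the read-out essentially unchanged and that all three numbers cluster closely. Compound 4 is therefore expected to fall near the others, with a number 1.1 percentage points lower from compound 2 to compound 4 (within the scatter) expected to stay within the scatter, giving an estimate of 23% with a range from 12% to 34%.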

Compound 4, a percentage reported as inhibition, in the whole organism at one dose (the size of the read-out at that dose, not a potency): 20.3%
The estimate for compound 4 lay 2.7 percentage points above the measured number; the measured number falls inside the stated range.
By their numbers in this assay, from the lowest: compounds 4, 3, 1 and 2 (each within the scatter of the next).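

The saturated ring carbon of the shared core now has a measured exchange: in this assay, 1H-pyrrol-2-yl in place of furan-2-yl gives a number 3.8 percentage points lower from compound 2 to compound 4 (within the scatter), the first step read at this position. This swap exchanges the ring oxygen for a ring nitrogen and brings a hydrogen-bond donor where the furan-2-yl group counts a hydrogen-bond acceptor, yet the read-out stays within the usual scatter, as it did for the earlier step on an aromatic carbon. Nothing measured here speaks to why the number behaves this way.

As far as these compounds go, whether a phenyl ring, an amine or a longer alkyl chain on this same carbon would also stay within the scatter remains open. So does whether the pyrrole exchange would read the same at other doses.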